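The source may report more compounds than this note shows. Statements on the series, on what has been measured and on what is new or still open speak of the compounds shown alone.

Measured compounds in a functional assay on HeLa cells (Homo sapiens) for cytotoxicity, read by CCK-8 assay; on this read-out higher numbers stand for weaker inhibition and lower numbers for stronger inhibition:
Compound 1 `Oc1ccc(-c2cc(-c3cccs3)cc(-c3ccccc3O)n2)cc1` gives > 50000 nM, a limit of the assay.
Compound 2 `Oc1ccc(-c2cc(-c3ccco3)cc(-c3ccccc3O)n2)cc1` gives > 50000 nM, likewise a limit.
Compound 3 `Oc1cccc(-c2cc(-c3ccccn3)cc(-c3ccccc3O)n2)c1` gives 2020 nM.

For the measured compounds named here, compound 3 thus holds the only number in this assay. Compound 1 and compound 2 stand at the limit of > 50000 nM in this assay, at which 2 of the 3 values shown sit. The step from compound 1 to compound 2, a step that the two limits leave unreadable from compound 1 to compound 2, lies between two limits and reads nothing. Compound 4 `Oc1ccc(-c2cc(-c3ccccn3)cc(-c3ccccc3O)n2)cc1` differs from compound 3 by 4-hydroxyphenyl in place of 3-hydroxyphenyl on an aromatic carbon. Going by the values given here, no measured step covers this change; compound 1 and compound 2 carry the 4-hydroxyphenyl of compound 4 yet other groups in place of the pyridin-2-yl, and both sit at the limit. Compound 4 is therefore expected to be weaker than compound 3, by a 5.0-fold higher number from compound 3 to compound 4 (0.69 log units; beyond the scatter), with a real chance of a limit. Compound 4 is estimated at 10000 nM, between 2500 nM and 50000 nM.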

Compound 4, half-maximal inhibitory concentration: > 50000 nM
Compound 4 was reported as a limit; the forecaster's own chance of this, stated with the estimate: 35%; middle value at least 5.0-fold (0.69 log units) from the limit.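

For the compounds shown here, with the same atoms joined differently, 4-hydroxyphenyl in place of 3-hydroxyphenyl, on the carbon next to the ring nitrogen, gives an at least 24-fold higher number from compound 3 to compound 4 (1.39 log units; beyond the scatter) in this assay, the first readable step here. Compound 4 stands at a limit, not a number: the limit of > 50000 nM in this assay, at which 3 of the 4 values shown sit.

The steps from compound 1 and from compound 2 to compound 4 cannot be read, and with 4-hydroxyphenyl in place pyridin-2-yl cannot be ranked against furan-2-yl or thiophen-2-yl.

The compounds shown leave open how furan-2-yl or thiophen-2-yl reads alongside 3-hydroxyphenyl. They also leave open whether a methoxy group or an amine in place of the hydroxyl of 3-hydroxyphenyl would hold the level of compound 3.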